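Adding an ethoxycarbonyl group to compound 2

This account rests on a few compounds, and the source may have more. Where it says the series, first, only, none or still open, it means among the compounds named here.

Among the measured compounds shown here, in a physicochemical assay for solubility, read by HPLC, at pH 7.4 (on this read-out higher numbers stand for higher solubility and lower numbers for lower solubility), compound 2 (`CCCCCOCc1cc(=O)c2cc([N+](=O)[O-])ccc2[nH]1`) gives 15000 nM and sits at the low end of the three numbers known so far. Compound 1 (`CCCCCOCc1cc(=O)c2cc(C(F)(F)F)ccc2[nH]1`) gives 15000 nM as well, so the two stand level, while compound 3 (`CCOCCCCc1cc(=O)c2cc([N+](=O)[O-])ccc2[nH]1`) gives 50000 nM and lies furthest from compound 2.

The next compound, compound 4 (`CCCCCOCc1[nH]c2ccc([N+](=O)[O-])cc2c(=O)c1C(=O)OCC`), keeps all of compound 2 and differs in one place (ethoxycarbonyl in place of hydrogen on an aromatic carbon): ethoxycarbonyl in place of hydrogen on an aromatic carbon, ortho to a (pentyloxy)methyl group.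

Two measured steps give a sense of scale. Nitro in place of trifluoromethyl gave no change at the digits printed from compound 1 to compound 2 (within the scatter) and 3-ethoxypropyl in place of pentyloxy gave a 3.3-fold higher number from compound 2 to compound 3 (0.52 log units; beyond the scatter) as the larger of the two. Neither step touches the carbon that changes here, so they guide the expected size but not its direction. The data cannot settle that direction, and a modest step toward a lower number in this assay is only a cautious expectation. The expected move is a 2.5-fold lower number from compound 2 to compound 4 (0.40 log units; beyond the scatter) and it remains an estimate. For compound 4 the estimated value is 6000 nM with an expected range from 1500 nM to 25000 nM until the measurement arrives.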

Compound 4, solubility: 15000 nM
For compound 4 the middle estimate is 2.5-fold (0.40 log units) below the measured one; low and high end bracket the measured number.
By their numbers in this assay, from the lowest: compounds 1, 2 and 4 (each within the scatter of the next); then compound 3.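

Among the compounds shown here, this is the first look at the aromatic carbon ortho to a (pentyloxy)methyl group, since compounds 1, 2 and 3 all carry hydrogen there, and in this assay placing ethoxycarbonyl on it gives no change at the digits printed from compound 2 to compound 4 (within the scatter) in this pair. The change is not a small one on paper: hydrogen gives way to a group of 5 heavy atoms with 2 hydrogen-bond acceptors, yet the solubility number of this nitro compound stays within the usual scatter, so this one substitution at this carbon leaves the read-out unmoved. No measurement shown here offers a reason for this result.

This is a single group on a single compound, so it leaves open whether a carboxylic acid, an amide or a small amine on the same carbon would also leave the number in place, and whether a longer ester chain would do so. It also leaves open whether ethoxycarbonyl would behave the same way with the trifluoromethyl group of compound 1 or the 3-ethoxypropyl chain of compound 3 in place.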